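A few compounds are considered here, and "the series" means these few. Any claim that something is new, unique, unknown or untested is made for them only; others in the source may bear on it.

Measured so far:
compound 1, `Nc1nc(Cl)c2ncn(C3CCC(CO)C3)c2n1` — > 100 ug/mL
compound 2, `Nc1nc(O)c2ncn(C3CCC(CO)C3)c2n1` — > 100 ug/mL
compound 3, `Nc1nc(Cl)c2nnn(C3C=CC(CO)C3)c2n1` — 1 ug/mL

The three compounds were tested in a functional assay on P388 cells (Mus musculus) for inhibition; on this read-out lower numbers stand for an effect already at smaller amounts and higher numbers for an effect only at larger amounts of compound. Compound 1 gives > 100 ug/mL, which is a limit of the assay and not a number. Compound 2 likewise gives > 100 ug/mL, again a limit. Going by the values given here, compound 3 is the only one with a number: in this assay compound 3 gives 1 ug/mL.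

Compound 1 and compound 2 differ in one place, (hydroxy in place of chloro on an aromatic carbon). The step between them, a step that the two limits leave unreadable from compound 1 to compound 2, cannot be read in size because of the limit of > 100 ug/mL in this assay, at which 2 of the 3 values shown sit. How the core of compound 3 differs from that of compound 1 is not broken down here.

Compound 4, `Nc1nc(O)c2nnn(C3C=CC(CO)C3)c2n1`, has not been measured. Among the compounds with values here, it differs from compound 3 by hydroxy in place of chloro on an aromatic carbon, the same change as the one from compound 1 to compound 2, made at a place described in identical words. Since the measured pair gives no readable size for this change, the expectation for compound 4 rests only on the value of compound 3 and on the wide range that an unreadable step leaves open. Compound 4 is therefore expected to give 10 ug/mL, within 1 ug/mL and 100 ug/mL. The step that this estimate means from compound 3 to compound 4 is a 10-fold higher number from compound 3 to compound 4 (1.00 log units; beyond the scatter), an expectation held loosely, with a real chance that this assay again reports only a limit.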

Compound 4, concentration for half-maximal effect: 4.5 ug/mL
The estimate for compound 4 lay 2.2-fold (0.35 log units) above the measured number; measured number inside the range.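

In this assay, putting hydroxy in place of chloro on an aromatic carbon gives a 4.5-fold higher number from compound 3 to compound 4 (0.65 log units; beyond the scatter), so on this core the change has a readable size, modest but beyond the usual scatter, and the product still gives a number and not a limit. The same change on the core of compound 1 cannot be read in size, so nothing here shows whether it has a similar size, or even the same direction, on both cores: the limit of > 100 ug/mL in this assay, at which 2 of the 4 values shown sit. Going by these compounds alone, the result therefore shows that the change can be carried to the core of compound 3 without the read-out being lost to the limit, but with only this one readable step it establishes no rule for carrying the change from core to core, and it gives no reason for the size seen.

All the compounds shown hold either chloro or hydroxy at this place, so how an amine, a methoxy group or a thiol there would read in this assay stays open. All of them also carry the same hydroxymethyl group, which leaves open what a carboxylic acid or a longer chain in its stead would give.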